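Purine hydroxamate-free benzamides: compound 4 from compound 2

The source may hold more compounds than are shown below. What is called first, only, known or untested is meant among the compounds shown, and "the series" means these compounds.

Three compounds carry the shared core. Compound 1 `CCCCn1cnc2c(Nc3cccc(Cl)c3)nc(NCOCc3ccc(/C=C/C(=O)Nc4ccccc4N)cc3)nc21` gives 4.76% in a functional assay on HCT-116 cells (Homo sapiens) for antiproliferative activity, read by CCK-8 assay, with a stated time of 72 h, tested at 2 uM; on this read-out lower numbers stand for a weaker effect and higher numbers for a stronger effect at the one concentration tested. Compound 2 `Nc1ccccc1NC(=O)c1ccc(Cn2cnc3c(NCc4ccccc4)nc(Cl)nc32)cc1` gives 68.3% and compound 3 `Nc1ccccc1NC(=O)c1ccc(Cn2cnc3c(Nc4ccc(-c5ccccn5)cc4)nc(Cl)nc32)cc1` gives 69.5%, so compound 2 stands second highest of the three numbers, within the scatter of compound 3 and well above compound 1, which differs from it in several places. For the measured compounds named here, the only single-place step, a number 1.2 percentage points higher from compound 2 to compound 3 (within the scatter), concerns the same aromatic carbon that is changed in compound 4 `CN1CCN(c2nc(Cl)nc3c2ncn3Cc2ccc(C(=O)Nc3ccccc3N)cc2)CC1`, where (4-methylpiperazin-1-yl in place of benzylamino on an aromatic carbon). Going by the values given here, no measured step covers the entering group itself, so the expected step of a number 13.3 percentage points lower from compound 2 to compound 4 (beyond the scatter) is none beyond the scatter, with wide uncertainty. Compound 4 is thus estimated at 55%, ranging from 25% to 78%.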

Compound 4, a percentage reported as inhibition, at one concentration (the size of the read-out at that concentration, not a potency): 71.6%
The estimate for compound 4 lay 16.6 percentage points below the measured number; the measured number falls inside the stated range.
By their numbers in this assay, from the lowest: compound 1; then compounds 2, 3 and 4 (each within the scatter of the next).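

In this assay, 4-methylpiperazin-1-yl in place of benzylamino on this aromatic carbon gives a number 3.3 percentage points higher from compound 2 to compound 4 (within the scatter), so the read-out does not separate the two groups. The earlier step changed only what sits on the nitrogen, whereas this one replaces the whole group, and the entering group has no hydrogen-bond donor and no aromatic ring. No measurement shown here offers an explanation for this result.

As far as these compounds go, whether a morpholine ring or a dimethylamino group on this carbon would give a similar number remains open. A single concentration also leaves open whether compound 2 and compound 4 differ in potency.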